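A few compounds are considered here, and "the series" means these few. Any claim that something is new, unique, unknown or untested is made for them only; others in the source may bear on it.

Compound 1 `N#CC1=C(N)Oc2c(c3nc4ccccc4nc3c3ccccc23)C12C(=O)N(Cc1cnnn1-c1cccc(Cl)c1)c1ccccc12`: in a functional assay on HCT-116 cells (Homo sapiens) for antiproliferative activity, read by MTT assay, with a stated time of 48 h (a higher number here means a weaker inhibitor, a lower number a stronger inhibitor), compound 1 gives > 50000 nM, a limit of the assay.
Compound 2 `COc1ccc(-n2nncc2CN2C(=O)C3(C(C#N)=C(N)Oc4c3c3nc5ccccc5nc3c3ccccc43)c3ccccc32)cc1`: in this assay compound 2 gives > 50000 nM, again a limit.
Compound 3 `CC(=O)Nc1ccc(-n2nncc2CN2C(=O)C3(C(C#N)=C(N)Oc4c3c3nc5ccccc5nc3c3ccccc43)c3ccccc32)cc1`: in this assay compound 3 gives > 50000 nM, also a limit.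

Compound 3 therefore stands only at the limit of > 50000 nM in this assay, at which 3 of the 3 values shown sit, and nowhere else on the numbers shown. Compound 4 `Cc1ccc(-n2nncc2CN2C(=O)C3(C(C#N)=C(N)Oc4c3c3nc5ccccc5nc3c3ccccc43)c3ccccc32)cc1C` differs from compound 3 in one place: 3,4-dimethylphenyl in place of 4-acetamidophenyl on an aromatic nitrogen. The measured steps at this aromatic nitrogen, a step that the two limits leave unreadable from compound 1 to compound 3 and a step that the two limits leave unreadable from compound 2 to compound 3, and likewise a step that the two limits leave unreadable from compound 1 to compound 2, are all unreadable, since each runs between two limits. No readable step exists to set a direction. Compound 4 is therefore expected in this assay to give about 50000 nM, between 20000 nM and 100000 nM, most probably as a limit once more. The step of a number no higher from compound 3 to compound 4 (the limit leaves the size open) is estimated to be none beyond the scatter.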

Compound 4, half-maximal inhibitory concentration: > 50000 nM
Compound 4: no number, only a limit (the forecaster's own chance of this, stated with the estimate: 80%); the middle value lies on the limit itself.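

For the compounds shown here, no step from compound 1, compound 2 or compound 3 to compound 4 can be read, since all four compounds stand at the same limit: the limit of > 50000 nM in this assay, at which 4 of the 4 values shown sit. The compounds shown leave open whether any group on this aromatic nitrogen can bring a measurable number in this assay.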